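Swapping the aryl group on the ring amine: compound 4

The source may hold more compounds than are shown below. What is called first, only, known or untested is meant among the compounds shown, and "the series" means these compounds.

Three compounds share one core and differ only in the aryl group attached to an amine nitrogen in a ring. Compound 1 `Cc1nc(-c2ccccc2)c(C(=O)N2CCN(c3cccc(C)c3C)CC2)o1` gives 35 nM in a functional assay on HL-60 cells (Homo sapiens) for inhibition, read by MTT assay, with a stated time of 72 h; a higher number here means a weaker inhibitor, a lower number a stronger inhibitor. Compound 2 `Cc1ccc(N2CCN(C(=O)c3oc(C)nc3-c3ccccc3)CC2)c(C)c1` gives 101 nM in this assay, and compound 3 `CCOc1cccc(N2CCN(C(=O)c3oc(C)nc3-c3ccccc3)CC2)c1` gives 151 nM in this assay. Compound 3 therefore carries the highest of the three numbers; its nearest neighbour is compound 2, with a 1.5-fold higher number from compound 2 to compound 3 (0.17 log units; within the scatter), while the widest gap is to compound 1, with a 4.3-fold higher number from compound 1 to compound 3 (0.63 log units; beyond the scatter).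

Compound 4 `COc1cc(OC)cc(N2CCN(C(=O)c3oc(C)nc3-c3ccccc3)CC2)c1` has not been measured yet. It differs from compound 3 in one place: 3,5-dimethoxyphenyl in place of 3-ethoxyphenyl on an amine nitrogen in a ring.

All three measured steps move the same aryl group, so all three bear on this change. Two of them are modest, a 2.9-fold higher number from compound 1 to compound 2 (0.46 log units; beyond the scatter) and a 4.3-fold higher number from compound 1 to compound 3 (0.63 log units; beyond the scatter), and one lies within the scatter, a 1.5-fold higher number from compound 2 to compound 3 (0.17 log units; within the scatter). Since compound 3 already sits at the high end and the two alkoxy-bearing groups resemble each other, a step of at most modest size is expected, most likely within the scatter, with the direction uncertain. The estimate for compound 4 is 190 nM in this assay, with a range from 80 nM to 450 nM, which is expected to amount to a 1.3-fold higher number from compound 3 to compound 4 (0.10 log units; within the scatter).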

Compound 4, half-maximal inhibitory concentration: 19.2 nM
The estimate for compound 4 lay 9.9-fold (1.00 log units) above the measured number; the measured number lies below the stated range.
By their numbers in this assay, from the lowest: compounds 4 and 1 (each within the scatter of the next); then compounds 2 and 3 (each within the scatter of the next).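

The earlier compounds shown here placed the 3-ethoxyphenyl group at the high end in this assay, but the change to 3,5-dimethoxyphenyl on the amine nitrogen gives a 7.9-fold lower number from compound 3 to compound 4 (0.90 log units; beyond the scatter) and shows that this position can respond far more strongly between two oxygen-bearing aryl groups than the earlier steps suggested. An oxygen-bearing aryl group therefore does not always go with a high number here: the same group also gives a 5.3-fold lower number from compound 2 to compound 4 (0.72 log units; beyond the scatter) and, set against the 2,3-dimethylphenyl group, gives a 1.8-fold lower number from compound 1 to compound 4 (0.26 log units; within the scatter) so that two quite different aryl groups reach numbers that cannot be told apart. No measurement shown here explains why these groups behave so differently.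

The change from compound 3 to compound 4 alters both the number of oxygen-bearing groups and the chain on the oxygen, so a 3-methoxyphenyl group would help to separate these two differences. A 3,5-dimethylphenyl group, with methyl groups in place of both methoxy groups, would show whether the oxygens are needed for a number this low.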